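A few compounds are considered here, and "the series" means these few. Any claim that something is new, unique, unknown or untested is made for them only; others in the source may bear on it.

Of the compounds shown here, three built on one shared core have so far been tested in a functional assay on HL-60 cells (Homo sapiens) for cytotoxicity, read by MTT assay, with a stated time of 24 h; on this read-out higher numbers stand for weaker inhibition and lower numbers for stronger inhibition. Compound 1 `CCCCn1cc(Cn2nc(N)c3c(C(F)(F)F)cc(-c4ccccc4)nc32)nn1` gives 36.7 ug/mL. Compound 2 `Nc1nn(Cc2cn(CCC(F)(F)C(F)(F)C(F)(F)C(F)(F)C(F)(F)C(F)(F)F)nn2)c2nc(-c3ccccc3)cc(C(F)(F)F)c12` gives 97.6 ug/mL. Compound 3 `Nc1nn(Cc2cn(CC(=O)Nc3ccccc3)nn2)c2nc(-c3ccccc3)cc(C(F)(F)F)c12` gives 96.3 ug/mL, the second highest of the three numbers; its gap to compound 2 lies within the scatter, whereas a 2.6-fold higher number from compound 1 to compound 3 (0.42 log units; beyond the scatter) lies beyond it. The next compound, compound 4 `Nc1nn(Cc2cn(CC(=O)Nc3ccccc3Br)nn2)c2nc(-c3ccccc3)cc(C(F)(F)F)c12`, differs from compound 3 by bromo in place of hydrogen on an aromatic carbon, placed on an aromatic carbon of a six-membered aromatic ring of carbon only, ortho to a large group. Within the data shown here, only one measured step is available, a 2.6-fold higher number from compound 1 to compound 3 (0.42 log units; beyond the scatter), and it concerns a different change, the swap of propyl for phenylcarbamoyl, so no measured step speaks directly to a bromine added to that ring. Compound 4 is therefore expected to show a step that stays within the scatter, a 1.1-fold lower number from compound 3 to compound 4 (0.03 log units; within the scatter). In this assay compound 4 is estimated at 90 ug/mL, with a range from 45 ug/mL to 180 ug/mL.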

Compound 4, half-maximal inhibitory concentration: 27.2 ug/mL
Estimate against measurement, compound 4: 3.3-fold (0.52 log units) above; the whole stated range lies above it.
By their numbers in this assay, from the lowest: compounds 4 and 1 (each within the scatter of the next); then compounds 3 and 2 (each within the scatter of the next).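

In this assay, placing bromo in place of hydrogen on the aromatic carbon ortho to a large group gives a 3.5-fold lower number from compound 3 to compound 4 (0.55 log units; beyond the scatter), so a single atom added to this ring changes the result beyond the usual scatter. The phenylcarbamoyl group of compound 3 had stood apart from the side chain of compound 1, but the (2-bromophenyl)carbamoyl group does not: the comparison gives a 1.3-fold lower number from compound 1 to compound 4 (0.13 log units; within the scatter), which leaves these two compounds indistinguishable here. Nothing measured here explains this shift.

Going by these compounds, whether the change is specific to bromo remains open, as chloro, methyl or methoxy on the same aromatic carbon could give a different result. On these data alone, it is also open whether bromo would give a similar step on another carbon of this ring.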